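The source may report more compounds than this note shows. Statements on the series, on what has been measured and on what is new or still open speak of the compounds shown alone.

Three compounds from this series have been run through an assay on Sf9 cells for inhibition of mitogen-activated protein kinase kinase kinase 14 (Homo sapiens), read by ADP-Glo, with a stated time of 60 min; a lower number here means a stronger inhibitor, a higher number a weaker inhibitor. Compound 1 `Cc1[nH]nc(N)c1-c1cccc(Br)c1` gives only a limit of the assay, > 100000 nM. Compound 2 `Cc1[nH]nc(N)c1-c1ccc(OCc2ccccc2)cc1` likewise gives a limit rather than a number, > 100000 nM. For the measured compounds named here, compound 3 `CCC(=O)n1nc(C)c(-c2ccc(Cl)c(Cl)c2)c1N` is the one compound with a measured value: in this assay compound 3 gives 27400 nM, a weak inhibition but a number nonetheless. The other two results sit at the limit of > 100000 nM in this assay, at which 2 of the 3 values shown sit. So compound 3 stands as the only compound of the three with a quantified potency, and nothing among the measured compounds shows how a single structural change shifts the read-out, since compound 1 and compound 2 differ from compound 3 in more than one place.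

Compound 4 `CCNC(=O)n1nc(C)c(-c2ccc(Cl)c(Cl)c2)c1N` has not yet been measured. It differs from compound 3 by ethylamino in place of ethyl on a carbonyl carbon, a propanoyl group becoming an ethylcarbamoyl group. Going by the values given here, with no measured step to lean on, the size of the step in this assay is expected to be small, likely within the usual scatter, and its direction is open. On that basis compound 4 is estimated at 25000 nM, with a range of 8000 nM to 80000 nM, which means an expected step of a 1.1-fold lower number from compound 3 to compound 4 (0.04 log units; within the scatter).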

Compound 4, half-maximal inhibitory concentration: > 100000 nM
Compound 4 gave a limit, no number (the forecaster's own chance of this, stated with the estimate: 20%); middle value at least 4.0-fold (0.60 log units) from the limit.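

For the compounds shown here, on the carbonyl carbon whose other neighbour is the aromatic nitrogen, ethylamino in place of ethyl gives the first step between two compounds that differ in one place, and in this assay it reads as an at least 3.6-fold higher number from compound 3 to compound 4 (0.56 log units; beyond the scatter). This shows that the position is not indifferent to the change from propanoyl to ethylcarbamoyl: a single added nitrogen carrying one hydrogen-bond donor is enough to move the read-out beyond the scatter, in the direction of a weaker inhibitor, though the full size of the step cannot be read since compound 4 gives a limit and not a number. Compound 4 thus joins compound 1 and compound 2 at the limit, which leaves compound 3 as the only compound with a quantified potency: the limit of > 100000 nM in this assay, at which 3 of the 4 values shown sit.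

The compounds shown leave open whether the shift follows the nitrogen itself or the hydrogen it carries, a question that a dimethylamino group on the same carbonyl carbon would address. They also leave open how a longer chain such as butanoyl, or a methoxy group, would read at this carbonyl carbon.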